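Notes on the amine series: from compound 3 to compound 4

The source may report more compounds than this note shows. Statements on the series, on what has been measured and on what is new or still open speak of the compounds shown alone.

Three compounds of the series have numbers in a functional assay on the whole organism (strain Wister albino) for inhibition, with Rattus norvegicus as the target, read by paw edema, with stated times of 1 h and 24 h, at a dose of 50 mg/kg by the intraperitoneal route; on this read-out lower numbers stand for less inhibition and higher numbers for more inhibition at the one dose given (going by the name of the read-out). Compound 1 `CCOC(=O)c1c(-c2ccc(Cl)cc2)cc(-c2ccccc2)nc1N1CCCCC1` gives 36.4%. Compound 2 `CCOC(=O)c1c(-c2ccc(Cl)cc2)cc(-c2ccccc2)nc1N1CCN(C)CC1` gives 53.2%. Compound 3 `CCOC(=O)c1c(-c2ccc(Cl)cc2)cc(-c2ccccc2)nc1Nc1ccc(C)cc1` gives 62.7%, the highest of the three numbers, though its gap to compound 2 is within the scatter, and only its gap to compound 1 lies beyond it. The measured steps are a number 16.8 percentage points higher from compound 1 to compound 2 (beyond the scatter), a number 26.3 percentage points higher from compound 1 to compound 3 (beyond the scatter) and a number 9.5 percentage points higher from compound 2 to compound 3 (within the scatter); all three exchange the whole group on the aromatic carbon of the shared core.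

Compound 4 `CCOC(=O)c1c(-c2ccc(Cl)cc2)cc(-c2ccccc2)nc1Nc1ccc(OC)cc1` keeps the (4-methylphenyl)amino arrangement of compound 3 and changes only its outer substituent: methoxy in place of methyl on an aromatic carbon. Going by the values given here, no measured step touches this part of the molecule, so the measured steps give no size for it. The step is expected to stay within the scatter, a number 2.7 percentage points lower from compound 3 to compound 4 (within the scatter). In this assay compound 4 is expected to give 60%, with a range from 45% to 75%.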

Compound 4, a percentage reported as inhibition, in the whole organism at one dose (the size of the read-out at that dose, not a potency): 39.6%
The estimate for compound 4 lay 20.4 percentage points above the measured number; the measured number lies below the stated range.
By their numbers in this assay, from the lowest: compounds 1 and 4 (each within the scatter of the next); then compounds 2 and 3 (each within the scatter of the next).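

In this assay, going by these compounds alone, the outer substituent on the aromatic ring, para to a large group, matters: methoxy in place of methyl gives a number 23.1 percentage points lower from compound 3 to compound 4 (beyond the scatter), a step of the size that the earlier compounds showed only on exchanging the whole group on the core. The standing of the arylamino arrangement therefore depends on this substituent, with a number 13.6 percentage points lower from compound 2 to compound 4 (beyond the scatter) and a number 3.2 percentage points higher from compound 1 to compound 4 (within the scatter), so the link through the amino group does not by itself carry the higher number of compound 3. Nothing available here explains the drop.

The compounds shown leave open whether the drop belongs to methoxy alone or extends to other replacements at this place, such as hydrogen, chlorine or hydroxyl. They also leave open whether a longer chain, such as ethoxy, follows methoxy.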